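Benzoylation of the aminomethyl arm in a cytotoxicity series

The compounds below may be only part of what the source reports. "The series", "measured", "known", "first", "only" and "open" are said of these compounds alone.

Of the compounds shown here, three sharing one core have been measured in a functional assay on HeLa cells (Homo sapiens) for cytotoxicity, read by MTT assay, with a stated time of 72 h; a lower number here means a stronger inhibitor, a higher number a weaker inhibitor. Compound 1 `CN1CCN(Cc2nnc(-c3cc(S(N)(=O)=O)c(SCc4ccccc4)cc3Cl)o2)CC1` gives 75000 nM, and compound 2 `NC(=O)c1cn(Cc2nnc(-c3cc(S(N)(=O)=O)c(SCc4ccccc4)cc3Cl)o2)nn1` gives 75000 nM; the step of no change at the digits printed from compound 1 to compound 2 (within the scatter) lies within the scatter. Compound 3 `NCc1nnc(-c2cc(S(N)(=O)=O)c(SCc3ccccc3)cc2Cl)o1` gives 490000 nM, the highest number of the three, with a 6.5-fold higher number from compound 1 to compound 3 (0.82 log units; beyond the scatter) and a 6.5-fold higher number from compound 2 to compound 3 (0.82 log units; beyond the scatter) both beyond the scatter, so compound 3 is the weakest inhibitor measured here.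

Compound 4 `NS(=O)(=O)c1cc(-c2nnc(CNC(=O)c3ccccc3)o2)c(Cl)cc1SCc1ccccc1` differs from compound 3 by benzoyl in place of hydrogen on an amine nitrogen. Among the compounds with values here, no measured step puts a benzoyl on that nitrogen, but the two steps that bear on it, a 6.5-fold higher number from compound 1 to compound 3 (0.82 log units; beyond the scatter) and a 6.5-fold higher number from compound 2 to compound 3 (0.82 log units; beyond the scatter), show that a bare amino on the saturated chain carbon bound to the aromatic carbon gives a higher number than either larger group placed there. By analogy, attaching a benzoyl to that amine is expected to move the number downward by a modest step, a 4.1-fold lower number from compound 3 to compound 4 (0.61 log units; beyond the scatter), in this assay. Compound 4 is therefore estimated at 120000 nM, within a range from 40000 nM to 400000 nM.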

Compound 4, half-maximal inhibitory concentration: 105000 nM
For compound 4 the middle estimate is 1.1-fold (0.06 log units) above the measured one, within the range that was stated.
By their numbers in this assay, from the lowest: compounds 1, 2 and 4 (each within the scatter of the next); then compound 3.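

In this assay, within the data shown here, benzoyl in place of hydrogen on the amine nitrogen gives a 4.7-fold lower number from compound 3 to compound 4 (0.67 log units; beyond the scatter), the only measured change made on that nitrogen itself rather than by exchanging the whole group on the saturated chain carbon. Benzamido also stands level with the two other groups at this place, with a 1.4-fold higher number from compound 2 to compound 4 (0.15 log units; within the scatter) and a 1.4-fold higher number from compound 1 to compound 4 (0.15 log units; within the scatter), so that among the four compounds only the bare amino of compound 3 stands apart. Nothing available on these compounds offers an explanation for this result.

On these data alone, whether the drop needs the aromatic ring of the benzoyl stays open, since an acetyl or a phenylacetyl on the same nitrogen would test this. Also open, as far as these compounds go, is whether any other group on this chain carbon can take the number lower than those of compounds 1, 2 and 4.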